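Isopropoxy in place of propylamino on a biguanide carbon

The compounds below may be only part of what the source reports. "The series", "measured", "known", "first", "only" and "open" are said of these compounds alone.

This account covers two measured compounds and one awaiting its number. Compound 1, `CCSc1ccc(NC(=N)NC(=N)NCCCCCCNC(=N)NC(=N)Nc2ccc(SCC)cc2)cc1`, and compound 2, `CCCNC(=N)NC(=N)Nc1ccc(Cl)cc1`, were both examined in a physicochemical assay for lipophilicity, in phosphate buffer, measured as octanol-water partition, at pH 11.5; a higher number here means a more lipophilic compound, a lower number a more polar compound. Compound 1 gives 5.58. Compound 2 gives 2.63, the lower of the two numbers, and the gap to compound 1 lies beyond the scatter. Compound 3, `CC(C)OC(=N)NC(=N)Nc1ccc(Cl)cc1`, has not yet been measured in this assay. It differs from compound 2 in one place: isopropoxy in place of propylamino on a carbon with a double bond to nitrogen.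

Among the compounds with values here, no measured pair shows this kind of change, so the size of the step cannot be read from the numbers at hand. Since one hydrogen-bond donor leaves and one hydrogen-bond acceptor enters with the same count of heavy atoms, the step from compound 2 to compound 3 is expected to be small and may not exceed the scatter, as a number 0.17 log units higher from compound 2 to compound 3 (within the scatter). Compound 3 is therefore estimated at 2.8, with a range from 2.2 to 3.4.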

Compound 3, partition coefficient: 2.64
The estimate for compound 3 lay 0.16 log units above the measured number; low and high end bracket the measured number.
By their numbers in this assay, from the lowest: compounds 2 and 3 (each within the scatter of the next); then compound 1.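

In this assay, within the data shown here, this change gives the first readable step at a carbon with a double bond to nitrogen (a number 0.01 log units higher from compound 2 to compound 3 (within the scatter)). Compound 2 and compound 3 stand within the scatter of each other, so at this place, isopropoxy in place of propylamino makes no difference beyond the scatter, even though a hydrogen-bond donor leaves and a hydrogen-bond acceptor enters. Nothing at hand accounts for this result.

The compounds shown leave open whether other groups at this place, such as methoxy, dimethylamino or a longer chain, would also stay within the scatter of compound 2. They also leave open whether the same exchange would give a similar step on another core, since compound 1 differs from compound 2 in more than one place.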